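A few compounds are considered here, and "the series" means these few. Any claim that something is new, unique, unknown or untested is made for them only; others in the source may bear on it.

Of the compounds shown here, three have been measured in a functional assay on HeLa S3 cells (Homo sapiens) for antiproliferative activity, read by XTT assay, with a stated time of 72 h; a higher number here means a weaker inhibitor, a lower number a stronger inhibitor. Within the data shown here, compound 1 `C#Cc1cn([C@@H]2O[C@H](CO)[C@@H](O)[C@H]2O)c2ncnc(C)c12` gives 14700 nM, the only reading of the three that is a true number. Compound 2 `Nc1nc(N)c2c(-c3ccco3)cn([C@@H]3O[C@H](CO)[C@@H](O)[C@H]3O)c2n1` reads > 20000 nM, which is a limit of the assay and not a number. Compound 3 `COc1nc(N)nc2c1c(-c1ccco1)cn2[C@@H]1O[C@H](CO)[C@@H](O)[C@H]1O` reads > 20000 nM, which is likewise a limit and not a number. Compound 3 therefore has no exact position, and the evidence around it is the limit of > 20000 nM in this assay, at which 2 of the 3 values shown sit.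

Compound 4 `COc1nc(N)nc2c1c(-c1ccoc1)cn2[C@@H]1O[C@H](CO)[C@@H](O)[C@H]1O` differs from compound 3 in one group: furan-3-yl in place of furan-2-yl on an aromatic carbon. In words, furan-3-yl stands in place of furan-2-yl on an aromatic carbon, and the two compounds have the same atoms, joined differently. Among the measured compounds shown here, the only measured step in this group of compounds is a step that the two limits leave unreadable from compound 2 to compound 3. That step exchanges amino for methoxy, leaves the furan untouched and has no readable size, so it gives no measure for this change. For the measured compounds named here, no measured pair shows the furan exchange itself. No step beyond the usual scatter is therefore expected in this assay. The expectation rests on compound 3 at > 20000 nM, a limit of the assay. The expected change is a number no higher from compound 3 to compound 4 (the limit leaves the size open). The estimate for compound 4 is 20000 nM, with an expected range from 8000 nM to 40000 nM.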

Compound 4, half-maximal inhibitory concentration: > 20000 nM
Compound 4: no number, only a limit (the forecaster's own chance of this, stated with the estimate: 75%); the middle value lies on the limit itself.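

In this assay compound 4 reads > 20000 nM, a limit of the assay and not a number, and compound 3 also carries only a limit, so no step can be read between compound 3 and compound 4. The compounds shown leave open what furan-3-yl in place of furan-2-yl does to antiproliferative activity, with most readings resting on one value: the limit of > 20000 nM in this assay, at which 3 of the 4 values shown sit.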